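The source may report more compounds than this note shows. Statements on the series, on what has been measured and on what is new or still open speak of the compounds shown alone.

Measured compounds in a functional assay (aorta) with Oryctolagus cuniculus as the target; on this read-out lower numbers stand for stronger inhibition and higher numbers for weaker inhibition:
compound 1, `Nc1ccnc(-c2nn(Cc3ccccc3F)c3ncccc23)n1`, gives 270 nM; 265000 nM (2 entries)
compound 2, `CCCCCCc1cnc(-c2nn(Cc3ccccc3F)c3ncccc23)nc1N`, gives 1040000 nM
compound 3, `N#Cc1cnc(-c2nn(Cc3ccccc3F)c3ncccc23)nc1N`, gives 391000 nM

Compound 3 holds the lowest of the two single numbers in this assay. Its nearest neighbour is compound 2, separated by the step of a 2.7-fold lower number from compound 2 to compound 3 (0.42 log units; beyond the scatter). Compound 1 yields no single number: the several entries of compound 1 in this assay, 270 nM; 265000 nM (2 entries) spans a very wide range and shows how far apart repeat measurements in this assay can fall.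

Compound 4 is `NCc1cnc(-c2nn(Cc3ccccc3F)c3ncccc23)nc1N`. It differs from compound 3 as follows: aminomethyl in place of cyano on an aromatic carbon. Going by the values given here, no measured step bears directly on this exchange. Among the compounds with values here, the only step at hand, a 2.7-fold lower number from compound 2 to compound 3 (0.42 log units; beyond the scatter), concerns a different group on that aromatic carbon and was modest. Compound 4 is therefore expected to show a step of a 1.0-fold higher number from compound 3 to compound 4 (0.01 log units; within the scatter) that need not exceed the scatter in either direction. For compound 4 the estimate in this assay is 400000 nM, within 100000 nM to 1500000 nM, set wide because the several entries of compound 1 in this assay, 270 nM; 265000 nM (2 entries) shows how strongly this assay can vary.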

Compound 4, half-maximal inhibitory concentration: 1400000 nM
The estimate for compound 4 lay 3.5-fold (0.54 log units) below the measured number; the measured number falls inside the stated range.
By their numbers in this assay, from the lowest: compound 3; then compounds 2 and 4 (each within the scatter of the next).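

At the aromatic carbon ortho to an amino group, this assay now shows that exchanging cyano for aminomethyl moves the read-out, with a 3.6-fold higher number from compound 3 to compound 4 (0.55 log units; beyond the scatter). The hexyl-bearing and aminomethyl-bearing compounds stay within the scatter of each other, with a 1.3-fold higher number from compound 2 to compound 4 (0.13 log units; within the scatter), so among the three groups at this place, only cyano stands apart, with the lower number. These modest steps carry limited weight, because repeat entries in this assay can fall very far apart: the several entries of compound 1 in this assay, 270 nM; 265000 nM (2 entries)

The compounds shown leave open whether a carboxylic acid or an amide at this carbon would read like cyano or like aminomethyl. They also leave open whether a short chain such as ethyl would read like hexyl.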